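Urea to amide switch on a pyrazole series

The compounds below may be only part of what the source reports. "The series", "measured", "known", "first", "only" and "open" are said of these compounds alone.

Measured compounds:
- compound 1, `COc1cc(Cl)cc(-c2nn(-c3cccc(NC(=O)c4ccc(Cl)c(Cl)c4)c3)cc2-c2ccncc2)c1`: 81.5%
- compound 2, `COc1cc(Cl)cc(-c2nn(-c3cccc(NC(=O)Nc4ccc(Cl)c(Cl)c4)c3)cc2-c2ccncc2)c1`: -70.3%

In a functional assay on COLO 205 cells (Homo sapiens) for inhibition, read by sulforhodamine B assay, with a stated time of 48 h, tested at 10 uM (a higher number here means a weaker effect of the compound at the concentration tested, a lower number a stronger effect), compound 2 gives -70.3%, the lowest of the two numbers; its nearest neighbour is compound 1, which in this assay gives 81.5%. For the measured compounds named here, the one step between them, a number 151.8 percentage points lower from compound 1 to compound 2 (beyond the scatter), is the only measured step that bears on the next compound.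

Compound 3, `COc1cc(Cl)cc(-c2nn(-c3cccc(NC(=O)c4cccc(C(F)(F)F)c4)c3)cc2-c2ccncc2)c1`, has not yet been measured. It differs from compound 2 at one place: 3-(trifluoromethyl)phenyl in place of (3,4-dichlorophenyl)amino on a carbonyl carbon. This change undoes the amide-to-urea exchange that defined the step from compound 1 to compound 2, though with a different aryl group on the carbonyl carbon. Since that step was large, a large step in this assay in the opposite direction is expected from compound 2 to compound 3, about a number 140.3 percentage points higher from compound 2 to compound 3 (beyond the scatter). Compound 3 is therefore estimated at 70%, with a range from 30% to 105%.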

Compound 3, a percentage reported as activity, at one concentration (the size of the read-out at that concentration, not a potency): 68.5%
Estimate against measurement, compound 3: 1.5 percentage points above, within the range that was stated.
By their numbers in this assay, from the lowest: compound 2; then compound 3; then compound 1.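

With its 3-(trifluoromethyl)phenyl on the carbonyl carbon, the amide compound 3 shows that the strong effect of urea compound 2 does not carry over to a second amide, a change that gives a number 138.8 percentage points higher from compound 2 to compound 3 (beyond the scatter) in this assay. Exchanging the aryl group within the amide pair gives only a number 13 percentage points lower from compound 1 to compound 3 (beyond the scatter) in the same assay, so both amides remain far from the urea, although this step also changes the aryl group. The data offered here give no measured explanation for these differences. Whether the urea link alone carries the effect remains open, since a urea bearing 3-(trifluoromethyl)phenyl is not among the compounds shown. Also open, on these data alone, is how a carbamate oxygen or a methylene in place of the urea nitrogen would behave.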